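Sulfonamide trimming on a shared core: compound 2 to compound 4

This account rests on a few compounds, and the source may have more. Where it says the series, first, only, none or still open, it means among the compounds named here.

Measured compounds:
- Compound 1 `COc1ccc(N)cc1-c1cnc2[nH]cc(-c3ccncc3)c2c1`, 110 nM
- Compound 2 `Cc1ccc(S(=O)(=O)Nc2cc(N)cc(-c3cnc4[nH]cc(-c5ccncc5)c4c3)c2)cc1`, 4.62 nM
- Compound 3 `Nc1ccc(-c2cnc3[nH]cc(-c4ccncc4)c3c2)cc1`, 25 nM

Of the compounds shown here, three sharing one core have been tested in an assay on isolated protein for inhibition of high affinity nerve growth factor receptor (Homo sapiens), read by 33P incorporation; on this read-out lower numbers stand for stronger inhibition and higher numbers for weaker inhibition. Compound 2 stands lowest of the three numbers; in this assay compound 2 gives 4.62 nM. Its nearest neighbour is compound 3, which gives 25 nM, a gap beyond the usual scatter. Furthest away is compound 1, which in this assay gives 110 nM, also well beyond the scatter. Compound 2 is thus the most potent of the three on the numbers shown.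

Compound 4 `CS(=O)(=O)Nc1cc(N)cc(-c2cnc3[nH]cc(-c4ccncc4)c3c2)c1` has not yet been measured. It differs from compound 2 in one place: methyl in place of 4-methylphenyl on a sulfonyl sulfur. Going by the values given here, no step between measured compounds covers this change, so its size is a matter of expectation only. Compound 3, which carries no sulfonamide at all, sits higher than compound 2, so some loss of potency is expected when the 4-methylphenyl shrinks to methyl, though the sulfonamide itself remains. The step from compound 2 to compound 4 is expected to be a 2.4-fold higher number from compound 2 to compound 4 (0.38 log units; beyond the scatter), a moderate weakening, likely beyond the scatter. Compound 4 is therefore estimated at 11 nM, within a range from 3.5 nM to 35 nM.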

Compound 4, half-maximal inhibitory concentration: 33.8 nM
Compound 4: middle estimate off by 3.1-fold (0.49 log units), on the low side, and the stated range covers the measured number.
By their numbers in this assay, from the lowest: compound 2; then compounds 3 and 4 (each within the scatter of the next); then compound 1.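

In this assay, the change at this position has a clear cost: methyl in place of 4-methylphenyl on a sulfonyl sulfur gives a 7.3-fold higher number from compound 2 to compound 4 (0.86 log units; beyond the scatter), with the sulfonamide nitrogen left in place. This is the only step shown that isolates this position, and it shows that the sulfonamide alone does not keep the low number of compound 2, since the potency also depends on what the sulfonyl sulfur carries. No measurement at hand bears on why the step has this size.

The compounds shown cannot say whether the loss follows the size of the group, or whether the ring itself matters, as an ethyl, a longer chain, a benzyl or an unsubstituted phenyl on the sulfonyl sulfur could tell. They also leave open what the methyl of the 4-methylphenyl contributes apart from its ring, and whether a carbonyl in place of the sulfonyl, as in an amide, would behave like either sulfonamide.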